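This account rests on a few compounds, and the source may have more. Where it says the series, first, only, none or still open, it means among the compounds named here.

Measured so far in a functional assay on HepG2 cells (Homo sapiens) for antiproliferative activity, read by sulforhodamine B assay, with a stated time of 72 h; a lower number here means a stronger inhibitor, a higher number a weaker inhibitor:

- Compound 1 `CC(C)[C@@H](NC(=O)OC(C)(C)C)C(=O)Nc1ccc2ncnc(Nc3cccc(Br)c3)c2c1`: > 50000 nM
- Compound 2 `CC(C)(C)OC(=O)NCC(=O)Nc1ccc2ncnc(Nc3cccc(C(F)(F)F)c3)c2c1`: > 50000 nM
- Compound 3 `CC(C)C[C@@H](NC(=O)OC(C)(C)C)C(=O)Nc1ccc2ncnc(Nc3cccc(C(F)(F)F)c3)c2c1`: > 50000 nM

Each of these entries is a limit of the assay and not a number. Compound 2 therefore has only a limit to its name, and it shares that position with the other two compounds, as the limit of > 50000 nM in this assay, at which 3 of the 3 values shown sit, shows.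

Compound 4 `CC(C)(C)OC(=O)NCC(=O)Nc1ccc2ncnc(Nc3cccc(Br)c3)c2c1` differs from compound 2 at a single place: bromo in place of trifluoromethyl on an aromatic carbon. In words, this is bromo in place of trifluoromethyl on an aromatic carbon.

Among the compounds with values here, the only measured step, a step that the two limits leave unreadable from compound 2 to compound 3, lies at a different place and offers no size to carry over. Compound 1 carries the same 3-bromophenyl as compound 4. Compound 1 gives > 50000 nM, which is again a limit.

No step beyond the scatter is therefore expected in this assay, in either direction. The expected change is a number no higher from compound 2 to compound 4 (the limit leaves the size open). For compound 4 the estimate is 50000 nM, with an expected range from 25000 nM to 100000 nM.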

Compound 4, half-maximal inhibitory concentration: 8300 nM
Estimate against measurement, compound 4: 6.0-fold (0.78 log units) above, outside the stated range (below it).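

In this assay, bromo in place of trifluoromethyl on the aromatic carbon gives an at least 6.0-fold lower number from compound 2 to compound 4 (0.77 log units; beyond the scatter), while hydrogen in place of isopropyl on the saturated chain carbon gives an at least 6.0-fold lower number from compound 1 to compound 4 (0.77 log units; beyond the scatter). Both places can therefore move the number, and among the compounds shown only compound 4 combines bromo on the aromatic ring with hydrogen on that chain carbon. Compound 1, compound 2 and compound 3 all stay at a limit of the assay, so neither step has a full size: the limit of > 50000 nM in this assay, at which 3 of the 4 values shown sit.

The compounds shown leave open how the number would respond to chloro or a nitrile on that aromatic carbon. They also leave open what a free amine would do in place of the carbamate, which every compound here retains.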